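A few compounds are considered here, and "the series" means these few. Any claim that something is new, unique, unknown or untested is made for them only; others in the source may bear on it.

Of the compounds shown here, three built on related cores have been tested in an assay on isolated protein for inhibition of protein deacetylase HDAC6 (Homo sapiens), read by fluorescence, with stated times of 10 min and 2 h; on this read-out higher numbers stand for weaker inhibition and lower numbers for stronger inhibition. Compound 1 `CCCN1CC(=O)N(Cc2ccc(C(=O)NO)cc2)C1=O` gives 53.4 nM. Compound 2 `O=C(NO)c1ccc(CN2C(=O)CN(Cc3ccccc3)C2=O)cc1` gives 12.5 nM. The two differ in one place, (phenyl in place of ethyl on a saturated chain carbon bound to an amide-type nitrogen in a ring), and that change made a 4.3-fold lower number from compound 1 to compound 2 (0.63 log units; beyond the scatter). Compound 3 `CCCC1(c2ccccc2)NC(=O)N(Cc2ccc(C(=O)NO)cc2)C1=O` gives 50.9 nM; this value and that of compound 1 lie within the scatter of each other. How the core of compound 3 differs from the core of compound 1 is not broken down here.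

Compound 4 `O=C(NO)c1ccc(CN2C(=O)NC(Cc3ccccc3)(c3ccccc3)C2=O)cc1` has not yet been measured in this assay. It differs from compound 3 by phenyl in place of ethyl on a saturated chain carbon bound to a saturated ring carbon. Going by the values given here, this is the same kind of change as the one from compound 1 to compound 2, but not the same: there the saturated chain carbon is bound to an amide-type nitrogen in a ring, here it is bound to a saturated ring carbon. Among the compounds shown this change has been measured only once, so the expectation rests on that single step. The step from compound 3 to compound 4 is expected to be a 2.3-fold lower number from compound 3 to compound 4 (0.36 log units; beyond the scatter), a lowering taken because the same kind of change gave a 4.3-fold lower number from compound 1 to compound 2 (0.63 log units; beyond the scatter), while the different place leaves its size less certain. Compound 4 is therefore expected to give 22 nM, with a likely range from 8 nM to 70 nM.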

Compound 4, half-maximal inhibitory concentration: 71.9 nM
The estimate for compound 4 lay 3.3-fold (0.51 log units) below the measured number, and the stated range ends below it.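

In this assay, swapping ethyl for phenyl on a saturated chain carbon bound to a saturated ring carbon gives a 1.4-fold higher number from compound 3 to compound 4 (0.15 log units; within the scatter), so on this core the change leaves the number within the usual scatter. The same kind of change therefore did not carry its effect from one core to the other, and a gain seen on one core in this series cannot simply be assumed on another: the same change on two cores in this assay, a 4.3-fold lower number (0.63 log units; beyond the scatter) from compound 1 to compound 2 and a 1.4-fold higher number (0.15 log units; within the scatter) from compound 3 to compound 4, 6.0-fold (0.78 log units) apart, beyond the scatter of two such steps. Going by these compounds alone, this does not show why the two steps differ: the cores differ and so does the place of the change, there is only one step for each, and two steps give no rule for any further core.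

The compounds shown leave open what a third core would do with this same change. They also leave open how either core would respond to a different group at this place, such as an amine, a carboxylic acid or a longer chain.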